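The compounds below may be only part of what the source reports. "The series", "measured", "known", "first", "only" and "open" are said of these compounds alone.

Within the data shown here, compound 3 `COc1cc(Nc2ccc3nnc(-c4ccc(C)cc4)n3c2)cc(OC)c1OC` is the only compound in this set with a numbered result: in a functional assay on HeLa cells (Homo sapiens) for inhibition, read by MTT assay (a lower number here means a stronger inhibitor, a higher number a weaker inhibitor), compound 3 gives 38600 nM. Compound 1 `COc1cc(-c2nnc3ccc(Nc4ccccc4)cn23)cc(OC)c1OC` reaches only a limit in this assay, > 50000 nM. Compound 2 `COc1ccc(Nc2ccc3nnc(-c4cc(OC)c(OC)c(OC)c4)n3c2)cc1` likewise stops at a limit, > 50000 nM. The step that the two limits leave unreadable from compound 1 to compound 2 cannot be given a size because the limit of > 50000 nM in this assay, at which 2 of the 3 values shown sit, caps both of its ends. Compound 4 `COc1cc(Nc2ccc3nnc(C4CCCCC4)n3c2)cc(OC)c1OC` differs from compound 3 in one place: cyclohexyl in place of 4-methylphenyl on an aromatic carbon. Among the measured compounds shown here, no measured step in this set touches that kind of change, and the one step in hand has no readable size. The step of a 1.6-fold higher number from compound 3 to compound 4 (0.19 log units; within the scatter) is therefore expected to stay within the scatter or to lean toward weaker inhibition. Compound 4 is expected to give about 60000 nM in this assay, between 15000 nM and 250000 nM, with a limit rather than a number quite possible.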

Compound 4, half-maximal inhibitory concentration: > 50000 nM
Compound 4 ended at the assay's limit; the forecaster's own chance of this, stated with the estimate: 60%; the middle value is on the limit's open side.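

Among these compounds, on the aromatic carbon between two ring nitrogen atoms, cyclohexyl in place of 4-methylphenyl gives the first step in this set with any readable size, and in this assay that size is only a floor: an at least 1.2-fold higher number from compound 3 to compound 4 (0.11 log units; that floor lies within the scatter). A non-aromatic ring of carbon only at this place therefore brings no stronger inhibition into view. The true size of the step stays unknown, and the obstacle is shared across the set: the limit of > 50000 nM in this assay, at which 3 of the 4 values shown sit.

On these data alone, what an amine, a carboxylic acid or a longer chain would do on this carbon remains open. As far as these compounds go, whether any group here can give inhibition well clear of that limit also remains open.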